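A few compounds are considered here, and "the series" means these few. Any claim that something is new, unique, unknown or untested is made for them only; others in the source may bear on it.

Three compounds have a number in a physicochemical assay for lipophilicity, measured as octanol-water partition; on this read-out lower numbers stand for lower lipophilicity and higher numbers for higher lipophilicity. Compound 1 `O=C(COc1cccc2ccccc12)N/N=C/c1c(O)ccc2ccccc12` gives 4.74, compound 2 `O=C(COc1cccc2ccccc12)N/N=C/c1ccc(O)cc1` gives 3.73, and compound 3 `COc1ccc(/C=N/NC(=O)COc2cccc3ccccc23)cc1OC` gives 3.51. Compound 2 thus stands second highest of the three: its value and that of compound 3 lie within the scatter of each other, while compound 1 sits beyond the scatter above it.

Compound 4 `O=C(COc1cccc2ccccc12)N/N=C/c1ccc(F)cc1` has not yet been measured. It differs from compound 2 in one place: fluoro in place of hydroxy on an aromatic carbon. For the measured compounds named here, no measured pair shows this change, so its size is an expectation only. Compound 4 is expected to come out higher in this assay than compound 2, by a step of a number 0.72 log units higher from compound 2 to compound 4 (beyond the scatter) beyond the scatter, so that compound 4 is estimated at 4.45, between 4.1 and 4.8.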

Compound 4, partition coefficient: 4.16
Estimate against measurement, compound 4: 0.29 log units above, and the stated range covers the measured number.
By their numbers in this assay, from the lowest: compounds 3 and 2 (each within the scatter of the next); then compound 4; then compound 1.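

Measured in this assay the exchange of hydroxy for fluoro on this aromatic carbon gives the first single-place step among these compounds, a number 0.43 log units higher from compound 2 to compound 4 (beyond the scatter) and modest in size. It shows that the read-out responds to a change at this position, para to a large group, with the rest of the structure held constant. Nothing available accounts for the step.

From the compounds shown here alone, whether an amine, a methyl or a carboxylic acid at this position would move the number, and in which direction, remains open. So does whether the same exchange would give a similar step on another core.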